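A few compounds are considered here, and "the series" means these few. Any claim that something is new, unique, unknown or untested is made for them only; others in the source may bear on it.

Going by the values given here, in an ADME assay on HEL cells (Homo sapiens) for cytotoxicity, with a stated time of 3 days (a lower number here means that less compound is tolerated, a higher number that more compound is tolerated), no measured compound has yet given an exact number. Compound 1 `CCCCCc1ccc(-c2cc3cn([C@H]4C[C@H](O)[C@@H](CO)O4)c(=O)nc3o2)cn1` reports > 50000 nM as a limit of the assay. Compound 2 `CCCCCc1ccc(-c2cc3cn([C@H]4C[C@H](O)[C@@H](CO)O4)c(=O)nc3o2)cc1` reports > 50000 nM as a limit too. Compound 3 `CCCc1ccc(C#Cc2cc3cn([C@H]4C[C@H](O)[C@@H](CO)O4)c(=O)nc3o2)cc1` stands at > 120000 nM which is likewise only a limit. Compound 4 `Cc1ccc(C#Cc2cc3cn([C@H]4C[C@H](O)[C@@H](CO)O4)c(=O)nc3o2)cc1` differs from compound 3 in one place hydrogen in place of ethyl on a saturated chain carbon bound to an aromatic carbon with hydrogen in place of ethyl on a saturated chain carbon bound to an aromatic carbon, so that propyl becomes methyl. Among the compounds with values here, no measured step is available to size this change, so none beyond the usual scatter is expected. The estimated step of a number no higher from compound 3 to compound 4 (the limit leaves the size open) reflects that expectation. For compound 4 the expected value is 120000 nM in this assay with an estimated range from 50000 nM to 250000 nM and the result may well be only a limit again.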

Compound 4, half-maximal cytotoxic concentration: 510000 nM
The estimate for compound 4 lay 4.3-fold (0.63 log units) below the measured number, and the stated range ends below it.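

Going by these compounds alone, the value of compound 3 is only a limit, and no step from it to compound 4 can be read. The compounds shown leave open how much the change from propyl to methyl shifts tolerance in this assay.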